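Swapping the Aryl Group Next to the Amine

A few compounds are considered here, and "the series" means these few. Any claim that something is new, unique, unknown or untested is made for them only; others in the source may bear on it.

Compound 1, `CC(C)(C)c1ccc(CNCCCNS(=O)(=O)c2cc(C(F)(F)F)cc(C(F)(F)F)c2)cc1`, gives 2700 nM in a functional assay on ASPC1 cells (Homo sapiens) for inhibition, read by MTT assay, with a stated time of 72 h; on this read-out lower numbers stand for stronger inhibition of growth and higher numbers for weaker inhibition of growth.
Compound 2, `COc1cccc(CNCCCNS(=O)(=O)c2cc(C(F)(F)F)cc(C(F)(F)F)c2)c1`, gives 3800 nM in this assay.
Compound 3, `O=S(=O)(NCCCNCC1COc2ccccc2O1)c1cc(C(F)(F)F)cc(C(F)(F)F)c1`, gives 2900 nM in this assay.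

Among these three numbers, compound 3 stands second highest. Its nearest neighbour is compound 1, with a 1.1-fold higher number from compound 1 to compound 3 (0.03 log units; within the scatter), and its furthest is compound 2, with a 1.3-fold lower number from compound 2 to compound 3 (0.12 log units; within the scatter); both steps lie within the scatter, so the three compounds cannot be told apart on this read-out.

Compound 4, `O=S(=O)(NCCCNCc1ccc(Cl)c(C(F)(F)F)c1)c1cc(C(F)(F)F)cc(C(F)(F)F)c1`, differs from compound 3 by 4-chloro-3-(trifluoromethyl)phenyl in place of 2,3-dihydro-1,4-benzodioxin-2-yl on a saturated chain carbon bound to an amine nitrogen. Every measured step changes the group at this same place: a 1.4-fold higher number from compound 1 to compound 2 (0.15 log units; within the scatter) and the two steps above. All three were within the scatter, so a change of the group on the saturated chain carbon bound to the amine nitrogen has so far left this assay essentially unmoved. The expectation for compound 4 is therefore a step of a 1.1-fold lower number from compound 3 to compound 4 (0.05 log units; within the scatter), that is, no change beyond the scatter. Compound 4 is estimated at 2600 nM, with a range from 1200 nM to 5600 nM.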

Compound 4, concentration for 50% growth inhibition: 9600 nM
Compound 4: the middle estimate sits 3.7-fold (0.57 log units) below what was measured, and the stated range ends below it.
By their numbers in this assay, from the lowest: compounds 1, 3 and 2 (each within the scatter of the next); then compound 4.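

For the compounds shown here, this position is less indifferent than the earlier compounds suggested: the group on a saturated chain carbon bound to an amine nitrogen can shift this assay beyond the scatter, with a 3.3-fold higher number from compound 3 to compound 4 (0.52 log units; beyond the scatter) and a 2.5-fold higher number from compound 2 to compound 4 (0.40 log units; beyond the scatter) and a 3.6-fold higher number from compound 1 to compound 4 (0.55 log units; beyond the scatter). All three steps point toward weaker inhibition of growth, while 4-(tert-butyl)phenyl, 3-methoxyphenyl and 2,3-dihydro-1,4-benzodioxin-2-yl remain within the scatter of one another, leaving 4-chloro-3-(trifluoromethyl)phenyl alone in standing apart. No measurement at hand explains this loss.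

The compounds shown do not separate the chlorine from the trifluoromethyl group, as none has a phenyl ring carrying only one of the two. They also leave open how a pyridine ring or a carboxylic acid at this place would read in this assay.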